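The compounds below may be only part of what the source reports. "The series", "measured", "known", "first", "only" and "open" are said of these compounds alone.

Measured so far in a functional assay on A549 cells (Homo sapiens) for antiproliferative activity, read by MTT assay, with a stated time of 24 h; a higher number here means a weaker inhibitor, a lower number a stronger inhibitor:
- compound 1, `Clc1ccc(C2=NN(c3ccc(-c4ccccc4)nn3)C(c3ccccc3)C2)cc1`: 96700 nM
- compound 2, `COc1ccc(C2=NN(c3ccc(-c4ccccc4)nn3)C(c3ccccc3)C2)cc1`: 75900 nM

Compound 2 holds the lowest of the two numbers; its nearest neighbour is compound 1, and the step of a 1.3-fold lower number from compound 1 to compound 2 (0.11 log units; within the scatter), methoxy in place of chloro on an aromatic carbon, stays within the scatter. The two compounds therefore cannot be ordered against each other on this assay.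

The next compound, compound 3, `COc1ccc(C2=NN(c3ccc(-c4ccccc4)nn3)C(c3cc(OC)c(OC)c(OC)c3)C2)cc1`, changes a different part of the shared core: 3,4,5-trimethoxyphenyl in place of phenyl on a saturated ring carbon. Among the compounds with values here, no measured step touches this position; the only step recorded, between compound 1 and compound 2, sits on the other aryl ring and was within the scatter, so it gives no guide to the size or direction of the new change. Within the data shown here, with no comparable step, the number for compound 3 is expected to stay near that of compound 2, and the estimated step of a 1.3-fold lower number from compound 2 to compound 3 (0.10 log units; within the scatter) is not expected to exceed the scatter. Compound 3 is therefore estimated at 60000 nM, with a range from 15000 nM to 150000 nM.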

Compound 3, half-maximal inhibitory concentration: > 100000 nM
Compound 3 ended at the assay's limit; the forecaster's own chance of this, stated with the estimate: 15%; middle value at least 1.6-fold (0.22 log units) away from the limit.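

In this assay, compound 3 gives > 100000 nM, which is a limit of the assay and not a number. Within the data shown here, this is the first reading at the saturated ring carbon next to the ring nitrogen, and the step is an at least 1.3-fold higher number from compound 2 to compound 3 (0.11 log units; that floor lies within the scatter). Putting 3,4,5-trimethoxyphenyl in place of phenyl there brings no sign of a lower number, but only a floor is known for the step, so the true size stays unknown and the floor alone does not separate the pair; the series has also now reached the top of what this read-out can report: the limit of > 100000 nM in this assay, at which 1 of the 3 values shown sits.

From the compounds shown here alone, whether a single methoxy, a hydroxyl, an amine or a carboxylic acid on the aromatic ring at this position would behave like the three methoxy groups together remains open. Also open, going by these compounds, is whether any group on this saturated ring carbon can give a number clearly lower than those of compound 1 and compound 2, which lie within the scatter of each other.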